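The source may hold more compounds than are shown below. What is called first, only, known or untested is meant among the compounds shown, and "the series" means these compounds.

Two compounds of the shared core stand measured in a functional assay on PC-3 cells (Homo sapiens) for cytotoxicity, read by MTT assay, with a stated time of 72 h; a higher number here means a weaker inhibitor, a lower number a stronger inhibitor. Compound 2 `Cn1ccc2c(Oc3ccc(NC(=O)c4nn(-c5ccccc5)ccc4=O)cc3)ccnc21` gives 58200 nM, the only number shown. Compound 1 `Cn1ccc2c(Oc3ccc(NC(=O)c4nn(-c5ccc(Cl)cc5)ccc4=O)cc3)ccnc21` returns only a limit, > 60000 nM. The step of an at least 1.0-fold lower number from compound 1 to compound 2 (0.01 log units; that floor lies within the scatter) lies within the scatter, with one value sitting at the limit of > 60000 nM in this assay, at which 1 of the 2 values shown sits. Compound 3 `Cn1ccc2c(Oc3ccc(NC(=O)c4nn(-c5ccc(Cl)c(F)c5)ccc4=O)cc3)ccnc21` carries 4-chloro-3-fluorophenyl in place of phenyl on an aromatic nitrogen, in words 4-chloro-3-fluorophenyl in place of phenyl on an aromatic nitrogen. Among the compounds with values here, the chloro part of this change is covered by that step and moved nothing beyond the scatter; the fluorine has no measured counterpart. The expected step is therefore a 1.0-fold higher number from compound 2 to compound 3 (0.01 log units; within the scatter), within the scatter. Compound 3 is estimated at 60000 nM, with a range from 30000 nM to 120000 nM.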

Compound 3, half-maximal inhibitory concentration: 32700 nM
For compound 3 the middle estimate is 1.8-fold (0.26 log units) above the measured one, within the range that was stated.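

With 4-chloro-3-fluorophenyl in place of phenyl on the aromatic nitrogen, this assay gives a 1.8-fold lower number from compound 2 to compound 3 (0.25 log units; within the scatter), so this change also stays inside the scatter. Fluoro in place of hydrogen on an aromatic carbon now has a reading, an at least 1.8-fold lower number from compound 1 to compound 3 (0.26 log units; that floor lies within the scatter), and that step is only a floor. Compound 1 gives a limit and not a number: the limit of > 60000 nM in this assay, at which 1 of the 3 values shown sits.

Fluoro alone on the phenyl remains unread, as does any other position on that ring. From the compounds shown here alone, whether an amine, a carboxylic acid or a methoxy group on this phenyl would move the number beyond the scatter also stays open.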